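From dimethoxyphenyl to naphthyl on a shared core

A few compounds are considered here, and "the series" means these few. Any claim that something is new, unique, unknown or untested is made for them only; others in the source may bear on it.

Measured in a functional assay on A549 cells (Homo sapiens) for inhibition, read by MTT assay, with a stated time of 48 h (a lower number here means a stronger inhibitor, a higher number a weaker inhibitor), so far:
- Compound 1 `Brc1ccc2[nH]cc(C(c3ccccc3)c3c[nH]c4ccc(Br)cc34)c2c1` gives 7500 nM
- Compound 2 `COc1ccc(C(c2c[nH]c3ccc(Br)cc23)c2c[nH]c3ccc(Br)cc23)cc1` gives 10000 nM
- Compound 3 `COc1ccc(OC)c(C(c2c[nH]c3ccc(Br)cc23)c2c[nH]c3ccc(Br)cc23)c1` gives 10000 nM

Compound 3 stands level with compound 2, and compound 1 lies within the scatter of both. Compound 4 `Brc1ccc2[nH]cc(C(c3ccc4ccccc4c3)c3c[nH]c4ccc(Br)cc34)c2c1` keeps the shared core. The change naphthalen-2-yl in place of 2,5-dimethoxyphenyl on a saturated chain carbon bound to two aromatic carbons puts naphthalen-2-yl in place of 2,5-dimethoxyphenyl on a saturated chain carbon bound to two aromatic carbons.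

Among the compounds with values here, three measured steps bear on this: a 1.3-fold higher number from compound 1 to compound 2 (0.12 log units; within the scatter) and a 1.3-fold higher number from compound 1 to compound 3 (0.12 log units; within the scatter) and finally no change at the digits printed from compound 2 to compound 3 (within the scatter) for a swap at this same carbon. Within the data shown here, all three stay small, but no measured compound carries naphthalen-2-yl, so the new group itself is untested. Going by a 1.3-fold higher number from compound 1 to compound 3 (0.12 log units; within the scatter) as a guide, no step beyond the scatter is expected in this assay for this change. The expected step is a 1.1-fold lower number from compound 3 to compound 4 (0.05 log units; within the scatter) on this reasoning. Compound 4 is estimated at 9000 nM with an expected range from 4000 nM to 20000 nM in this measurement.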

Compound 4, half-maximal inhibitory concentration: 8500 nM
Estimate against measurement, compound 4: 1.1-fold (0.02 log units) above; the measured number falls inside the stated range.
By their numbers in this assay, from the lowest: compounds 1, 4, 2 and 3 (each within the scatter of the next).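

Putting naphthalen-2-yl, with 2 six-membered aromatic rings of carbon only and 0 hydrogen-bond acceptors, in place of 2,5-dimethoxyphenyl, with 2 hydrogen-bond acceptors, gives in this assay a 1.2-fold lower number from compound 3 to compound 4 (0.07 log units; within the scatter). Measured against the simpler groups at the same carbon, naphthalen-2-yl gives a 1.2-fold lower number from compound 2 to compound 4 (0.07 log units; within the scatter) and a 1.1-fold higher number from compound 1 to compound 4 (0.05 log units; within the scatter). Across these four compounds, neither the second aromatic ring nor the absence of the methoxy oxygens moves the number beyond the scatter, and nothing measured here offers an explanation.

From the compounds shown here alone, all four compounds carry only aromatic groups at this carbon, so it remains open whether an amine, a carboxylic acid or a longer chain there would give a step beyond the scatter. The bromines on the shared core also stay fixed, leaving open what chlorine or hydrogen in their place would do.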